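This account rests on a few compounds, and the source may have more. Where it says the series, first, only, none or still open, it means among the compounds named here.

Compound 1 `CC(C)C1(Cc2ccccc2)OS(=O)(=O)C=C1OCc1ccccc1` and compound 2 `CCC1(Cc2ccccc2)OS(=O)(=O)C=C1OCc1cccc(Cl)c1` share a core and differ in two places. In an ADME assay on HEL cells (Homo sapiens) for cytotoxicity, with a stated time of 3 days (on this read-out lower numbers stand for higher toxicity in this test and higher numbers for lower toxicity in this test), compound 1 gives 200000 nM, while compound 2 gives 50000 nM, the lower of the two numbers and beyond the scatter from compound 1. Compound 3 `CCC1(Cc2ccccc2)OS(=O)(=O)C=C1OCc1ccccc1` follows from compound 2 by hydrogen in place of chloro on an aromatic carbon. Among the measured compounds shown here, no measured step isolates this change, so compound 3 is expected to show a step of a 2.0-fold higher number from compound 2 to compound 3 (0.30 log units; within the scatter) upward, modest and near the edge of the scatter. Compound 3 is therefore estimated at 100000 nM, within 40000 nM to 250000 nM.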

Compound 3, half-maximal cytotoxic concentration: 200000 nM
The estimate for compound 3 lay 2.0-fold (0.30 log units) below the measured number; the measured number falls inside the stated range.
By their numbers in this assay, from the lowest: compound 2; then compounds 1 and 3 (each within the scatter of the next).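

In this assay the chloro group now stands alone as a change: hydrogen in its place on the aromatic carbon gives a 4.0-fold higher number from compound 2 to compound 3 (0.60 log units; beyond the scatter) and so moves the read-out beyond the scatter. Hydrogen in place of methyl on the saturated chain carbon gives no change at the digits printed from compound 1 to compound 3 (within the scatter) and so leaves the read-out unmoved in this pair. Nothing measured here accounts for either step.

Only chloro and hydrogen are shown at this aromatic carbon. As far as these compounds go, whether a methoxy group, a fluoro group or an amine there would give a similar step remains open.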